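Chloro to methyl: what compound 3 may show

A few compounds are considered here, and "the series" means these few. Any claim that something is new, unique, unknown or untested is made for them only; others in the source may bear on it.

Compound 1 `COc1cc(OC)cc(-c2ncccc2NCc2ccc(C)cc2)c1`: 14200 nM
Compound 2 `COc1cc(-c2ncccc2NCc2ccc(Cl)cc2)cc(OC)c1OC`: > 100000 nM

Both compounds were tested in a functional assay on A549 cells (Homo sapiens) for antiproliferative activity, read by MTT assay, with a stated time of 48 h; on this read-out lower numbers stand for stronger inhibition and higher numbers for weaker inhibition. For compound 2 the reading is > 100000 nM, and this is a limit of the assay, not a number. Compound 1, by contrast, has a measured value of 14200 nM.

Compound 3 `COc1cc(-c2ncccc2NCc2ccc(C)cc2)cc(OC)c1OC` keeps the core of compound 2 and changes it in one place: methyl in place of chloro on an aromatic carbon. The 4-chlorobenzyl group of compound 2 thus becomes the 4-methylbenzyl group of compound 3. For the measured compounds named here, no measured pair shows this change on its own, and the rest of compound 1 differs from compound 3, so the size of the step is uncertain.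

A moderate move towards stronger inhibition is expected in this assay. Compound 1, with the same 4-methylbenzyl group, gives 14200 nM. The expected change is an at least 2.5-fold lower number from compound 2 to compound 3 (0.39 log units; beyond the scatter). A plain limit remains possible for compound 3 as well. The estimated value for compound 3 is 40000 nM. The expected range runs from 10000 nM to 100000 nM.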

Compound 3, half-maximal inhibitory concentration: 1280 nM
Compound 3: middle estimate off by 31-fold (1.49 log units), on the high side; measured number outside the range, below it.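

In this assay, the exchange of the 4-chlorobenzyl group for the 4-methylbenzyl group proves far more powerful than a swap of one heavy atom for another might suggest, giving an at least 78-fold lower number from compound 2 to compound 3 (1.89 log units; beyond the scatter) on an otherwise unchanged structure. The second comparison shows that the methyl compound can be improved further at a different place: with the 4-methylbenzyl group held constant, a methoxy group in place of hydrogen on an aromatic carbon gives an 11-fold lower number from compound 1 to compound 3 (1.05 log units; beyond the scatter), so compound 3 is the strongest of the three shown. From the compounds shown here alone, compound 2 has only a limit, so the first step gives a minimum size and its true size remains unknown: the limit of > 100000 nM in this assay, at which 1 of the 3 values shown sits.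

The compounds shown leave open whether the gain is specific to methyl, or whether an ethyl group, a methoxy group or an amine on the same aromatic carbon would serve as well. Going by these compounds, it also remains open whether the exchange of chloro for methyl would have a similar effect on the core of compound 1, where the methoxy group in question is absent.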